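This account rests on a few compounds, and the source may have more. Where it says the series, first, only, none or still open, it means among the compounds named here.

Compound 2 `Cc1ccc2nc(/N=C3\C(=O)N(CN4CCCCC4)c4ccccc43)sc2c1` and compound 1 `CCN(CC)CN1C(=O)/C(=N\c2nc3ccc(C)cc3s2)c2ccccc21` share one core and differ only in one group: diethylamino in place of piperidin-1-yl on a saturated chain carbon bound to an amide-type nitrogen in a ring. In a functional assay on MDA-MB-468 cells (Homo sapiens) for cytotoxicity, read by sulforhodamine B assay, with a stated time of 48 h (a higher number here means a weaker inhibitor of growth, a lower number a stronger inhibitor of growth), compound 2 gives 65600 nM and compound 1 gives 63500 nM, so that this change made a 1.0-fold lower number from compound 2 to compound 1 (0.01 log units; within the scatter). Compound 3 `O=C1C(=O)N(CN2CCCCC2)c2cccc(Cl)c21` is built on a different core, and the difference between the two cores is not broken down here; in this assay compound 3 gives 82800 nM. Compound 4 `CCN(CC)CN1C(=O)C(=O)c2c(Cl)cccc21` is compound 3 with the same change: diethylamino in place of piperidin-1-yl on a saturated chain carbon bound to an amide-type nitrogen in a ring. Because the earlier step of a 1.0-fold lower number from compound 2 to compound 1 (0.01 log units; within the scatter) stayed within the scatter, the step from compound 3 to compound 4 is expected to be about as small, a 1.0-fold lower number from compound 3 to compound 4 (0.01 log units; within the scatter). Compound 4 is therefore estimated at 80000 nM in this assay, most likely between 40000 nM and 160000 nM.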

Compound 4, concentration for 50% growth inhibition: 28300 nM
Beside the measured number, compound 4's estimate is 2.8-fold (0.45 log units) above it, outside the stated range (below it).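

In this assay, putting diethylamino in place of piperidin-1-yl gives a 2.9-fold lower number from compound 3 to compound 4 (0.47 log units; beyond the scatter), so this change does not carry over from one core to the other with the same size: the same change on two cores in this assay, a 1.0-fold lower number (0.01 log units; within the scatter) from compound 2 to compound 1 and a 2.9-fold lower number (0.47 log units; beyond the scatter) from compound 3 to compound 4, 2.8-fold (0.45 log units) apart, beyond the scatter of two such steps

On the core of compound 3 the swap goes with stronger growth inhibition, whereas on the core of compound 2 it makes no readable difference. Two pairs do not show why the steps differ, or how the change would behave on a third core.

As far as these compounds go, it remains open whether a morpholine or a dimethylamino group on the same chain carbon would behave like diethylamino on either core. Also open, from the compounds shown here alone, is which feature of the two cores sets the steps apart.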